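The source may hold more compounds than are shown below. What is called first, only, known or untested is meant among the compounds shown, and "the series" means these compounds.

Series notes on the shared core. Compound 1 `NCCOc1ccc([C@H]2CC[C@]3(CC2)OOC2(O3)C3CC4CC(C3)CC2C4)cc1` and compound 2 `NC(=O)C1CCN(Cc2ccc([C@H]3CC[C@]4(CC3)OOC3(O4)C4CC5CC(C4)CC3C5)cc2)CC1` have been run in an ADME assay on microsomes from liver (Homo sapiens) for metabolic stability, read by LC-MS, tested at 1 uM; on this read-out lower numbers stand for slow clearance and higher numbers for fast clearance. In this assay compound 1 gives only a limit, < 7 mL.min-1.g-1. In this assay, among the measured compounds shown here, compound 2 gives 10 mL.min-1.g-1, the only number in the set; the step of an at least 1.4-fold higher number from compound 1 to compound 2 (0.15 log units; that floor lies within the scatter) is anchored on that limit (the limit of < 7 mL.min-1.g-1 in this assay, at which 1 of the 2 values shown sits). Compound 3 `CC(C)(CN)Oc1ccc([C@H]2CC[C@]3(CC2)OOC2(O3)C3CC4CC(C3)CC2C4)cc1` is unmeasured; it differs from compound 2 in this way: 1-(aminomethyl)-1-methylethoxy in place of (4-carbamoylpiperidin-1-yl)methyl on an aromatic carbon. With the step from compound 1 to compound 2 as the sole relevant one, compound 3 is expected to sit near or under the limit, estimated at 7 mL.min-1.g-1 (range 3 mL.min-1.g-1 to 15 mL.min-1.g-1), a step of a 1.4-fold lower number from compound 2 to compound 3 (0.15 log units; within the scatter) within the scatter.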

Compound 3, intrinsic clearance in microsomes: < 7 mL.min-1.g-1
Compound 3 was reported as a limit; the forecaster's own chance of this, stated with the estimate: 45%; the middle value sits exactly at the limit.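

In this assay, the 1-(aminomethyl)-1-methylethoxy group on this aromatic carbon gives a second limit, so a chain with no ring also reaches it when carrying the added methyl groups. The change from (4-carbamoylpiperidin-1-yl)methyl gives an at least 1.4-fold lower number from compound 2 to compound 3 (0.15 log units; that floor lies within the scatter), and the step between compound 1 and compound 3 cannot be read. Most of the set now rests on one limit: the limit of < 7 mL.min-1.g-1 in this assay, at which 2 of the 3 values shown sit.

As far as these compounds go, how far compound 1 and compound 3 lie under that limit stays open. Also open, from the compounds shown here alone, is what a carboxylic acid or a longer amine chain would give on this aromatic carbon.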